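Shortening the Ether Chain by Two Carbons

The source may hold more compounds than are shown below. What is called first, only, known or untested is meant among the compounds shown, and "the series" means these compounds.

Two compounds share one core and differ only in the group hanging from the oxygen on the aromatic ring. Compound 1, `CS(=O)(=O)NC(=O)c1cc(Cl)c(OCC2CCCCC2)cc1F`, carries a cyclohexylmethyl group and gives 1.4 in a physicochemical assay for lipophilicity, at pH 7.4; a lower number here means a more polar compound, a higher number a more lipophilic compound. Compound 2, `CS(=O)(=O)NC(=O)c1cc(Cl)c(OCCC2CCCCC2)cc1F`, carries a 2-cyclohexylethyl group and gives 1.5 in the same assay. Compound 2 stands highest of the two numbers, but its nearest neighbour is compound 1, and the step of a number 0.10 log units higher from compound 1 to compound 2 (within the scatter), so the two are not distinguishable by this measurement.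

Within the data shown here, compound 3, `CS(=O)(=O)NC(=O)c1cc(Cl)c(OC2CCCCC2)cc1F`, has not yet been measured. cyclohexyl in place of 2-cyclohexylethyl on an oxygen on an aromatic ring The only measured step that bears on this change is the one from compound 1 to compound 2, where one chain carbon was added and the number moved only within the scatter. Compound 3 goes the other way, from 2-cyclohexylethyl to cyclohexyl, so the step is expected to run in the opposite direction and to be larger than the measured one, an expected change of a number 0.30 log units lower from compound 2 to compound 3 (within the scatter). The estimate for compound 3 in this assay is therefore 1.2, with a range from 0.9 to 1.5.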

Compound 3, distribution coefficient: 1.3
Beside the measured number, compound 3's estimate is 0.10 log units below it; measured number inside the range.
By their numbers in this assay, from the lowest: compounds 3, 1 and 2 (each within the scatter of the next).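

In this assay, the step of a number 0.20 log units lower from compound 2 to compound 3 (within the scatter) comes with cyclohexyl in place of 2-cyclohexylethyl on an oxygen on an aromatic ring, and the step of a number 0.10 log units lower from compound 1 to compound 3 (within the scatter) comes with cyclohexyl in place of cyclohexylmethyl at that same place. The earlier pair compared only cyclohexylmethyl and 2-cyclohexylethyl, whereas all three groups can now be set side by side: each holds one six-membered non-aromatic ring of carbon only, and this measurement separates none of them, since every step among them lies within the scatter. No measurement at hand explains why these steps are so small.

The compounds shown leave open how the number would respond to a different kind of group on this oxygen, such as a chain ending in an amine, a chain ending in a carboxylic acid, or a longer chain such as 4-cyclohexylbutyl. They also leave open whether these three groups, so close together here, would stay as close in a biological test on the shared core.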